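The source may report more compounds than this note shows. Statements on the series, on what has been measured and on what is new or still open speak of the compounds shown alone.

Working notes on the series.

Among the compounds with values here, compound 1 `Cc1cc(Nc2cc(N3CCN(C)CC3)nc(Nc3ccc([N+](=O)[O-])cc3)n2)n[nH]1` is the reference point; in a functional assay on HL-60 cells (Homo sapiens) for antiproliferative activity, read by CCK-8 assay, with a stated time of 72 h (a lower number here means a stronger inhibitor, a higher number a weaker inhibitor), compound 1 gives 69.8 nM, the lowest of the two numbers so far, with compound 2 the nearest at a gap beyond the scatter. Compound 2 `COc1cccc(Nc2nc(Nc3cc(C)[nH]n3)cc(N3CCN(C)CC3)n2)c1` gives 397 nM, and the step of a 5.7-fold higher number from compound 1 to compound 2 (0.75 log units; beyond the scatter) is the only one measured; it alters the group on the same nitrogen and reads as (4-nitrophenyl)amino to (3-methoxyphenyl)amino, so it bears on the present question only in part.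

Compound 3 `Cc1cc(Nc2cc(N3CCN(C)CC3)nc(Nc3cccc([N+](=O)[O-])c3)n2)n[nH]1` differs from compound 1 as 3-nitrophenyl in place of 4-nitrophenyl on a nitrogen on an aromatic ring; the same atoms are joined differently, and the change cut one bond further out reads (4-nitrophenyl)amino to (3-nitrophenyl)amino. Within the data shown here, the one step on this nitrogen went weaker, but it moved both the group and its attachment point, so a smaller shift in the same direction is expected here, possibly none beyond the scatter. Compound 3 is estimated at 150 nM, range 50 nM to 500 nM, a step of a 2.1-fold higher number from compound 1 to compound 3 (0.33 log units; beyond the scatter).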

Compound 3, half-maximal inhibitory concentration: 90.9 nM
The estimate for compound 3 lay 1.7-fold (0.22 log units) above the measured number; the range from low to high includes it.
By their numbers in this assay, from the lowest: compounds 1 and 3 (each within the scatter of the next); then compound 2.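

In this assay, 3-nitrophenyl in place of 4-nitrophenyl on this nitrogen gives a 1.3-fold higher number from compound 1 to compound 3 (0.11 log units; within the scatter), so moving the nitro group between these two attachment points does not separate compound 1 from compound 3. With the attachment point held, nitro in place of methoxy on an aromatic carbon gives a 4.4-fold lower number from compound 2 to compound 3 (0.64 log units; beyond the scatter); the gap seen earlier between the nitro and methoxy compounds therefore follows the change of group, not the change of attachment point, among these three compounds. No measured data bear on what lies behind either step.

Whether methoxy is equally insensitive to its attachment point remains open, since only one methoxy compound is shown. Also open, as far as these compounds go, is how an amine, a nitrile or a carboxylic acid in place of nitro on the phenyl ring would read.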